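The source may report more compounds than this note shows. Statements on the series, on what has been measured and on what is new or still open speak of the compounds shown alone.

Measured in a functional assay on cells (Cancer cell lines, Homo sapiens) for inhibition; on this read-out higher numbers stand for weaker inhibition of growth and lower numbers for stronger inhibition of growth:
- compound 1 `Nc1ccc(-c2nc3cc(F)ccc3s2)cc1` gives 11500 nM in this test
- compound 2 `Cc1cc(-c2nc3cccc(F)c3s2)ccc1N` gives 40 nM in this test

Of these two compounds, compound 2 has the lower number, and the gap to compound 1 lies well beyond the usual scatter of repeated measurements. Compound 2 is therefore the stronger growth inhibitor of the pair. The two differ in more than one place, so their values alone cannot show what any single change does.

The next compound is compound 3 `Cc1cc(-c2nc3ccccc3s2)ccc1N`, which has hydrogen in place of fluoro on an aromatic carbon (the change counts as hydrogen in place of fluoro on an aromatic carbon and is the only one). Among the compounds with values here, no measured pair differs in just one place, so the data offer no direct guide to the size of such a step. In this assay, the expectation is therefore for no step beyond the scatter, in either direction, starting from compound 2 at 40 nM as the closest reference. In numbers, the expected change is a 1.3-fold lower number from compound 2 to compound 3 (0.12 log units; within the scatter) and remains uncertain. The estimated value for compound 3 is 30 nM with an expected range from 5 nM to 250 nM in this test.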

Compound 3, concentration for 50% growth inhibition: < 10 nM
Compound 3 gave a limit, no number (the forecaster's own chance of this, stated with the estimate: 15%); at least 3.0-fold (0.47 log units) between middle value and limit.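

Within the data shown here, this is the first pair that differs in one place only, so it gives the first direct reading of a single change: with hydrogen in place of fluoro on an aromatic carbon of the six-membered aromatic ring of carbon only, this assay shows an at least 4.0-fold lower number from compound 2 to compound 3 (0.60 log units; beyond the scatter). At this position, then, the fluoro is not needed for growth inhibition, and the compound without it is the stronger inhibitor of the pair, by a margin beyond the scatter. The value for compound 3 is a limit and not a number, so the step gives only a minimum size and the full gap stays unknown: the limit of < 10 nM in this assay, at which 1 of the 3 values shown sits.

As far as these compounds go, whether hydrogen is the best choice at this position remains open, since a chloro or a methoxy group there could give a weaker or a stronger result, and a single pair cannot tell. Compound 1 differs from compound 2 and compound 3 in more than one place, so how much of its far weaker result comes from each of those differences also stays unresolved.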